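This account rests on a few compounds, and the source may have more. Where it says the series, first, only, none or still open, it means among the compounds named here.

Measured compounds in this assay:

Compound 1, `O=c1cc(Cn2cc(-c3cc(F)cc(F)c3)nn2)c2ccc(O)cc2o1`: in this assay compound 1 gives > 100000 nM, which is a limit of the assay rather than a number.

Compound 2, `CCCCc1ccc(-c2cn(Cc3cc(=O)oc4cc(O)ccc34)nn2)cc1`: in this assay compound 2 gives 69800 nM.

The read-out is a functional assay on CFPAC-1 cells (Homo sapiens) for inhibition, read by MTT assay, with a stated time of 72 h; on this read-out higher numbers stand for weaker inhibition and lower numbers for stronger inhibition. Among the two values shown, compound 2 is the only one with an actual number; the other sits at a limit, as stated in the limit of > 100000 nM in this assay, at which 1 of the 2 values shown sits. Compound 2 thus stands as the one reference point from which a new compound can be judged.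

Compound 3, `CCCCCCc1ccc(-c2cn(Cc3cc(=O)oc4cc(O)ccc34)nn2)cc1`, is not yet measured. It differs from compound 2 in one place: ethyl in place of hydrogen on a saturated chain carbon, four bonds along the chain from an aromatic carbon. In other words, the butyl chain on the outer ring of compound 2 is lengthened to a hexyl chain, with nothing else touched.

Among the compounds with values here, no step between two measured compounds is available to guide this change, so the expectation rests on compound 2 alone. A chain extension of this kind is expected to move the value only modestly, most likely toward stronger inhibition but not clearly beyond the scatter of repeated measurements. The step from compound 2 to compound 3 is therefore expected to be about a 1.6-fold lower number from compound 2 to compound 3 (0.19 log units; within the scatter). Compound 3 is estimated to give 45000 nM, with a likely range from 18000 nM to 110000 nM.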

Compound 3, half-maximal inhibitory concentration: > 100000 nM
Compound 3: only a limit was reported; the forecaster's own chance of this, stated with the estimate: 30%; middle value at least 2.2-fold (0.34 log units) from the limit.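

In this assay compound 3 gives > 100000 nM, which is a limit of the assay and not a number. Within the data shown here, this is the first look at a change along the chain on the outer ring: going from butyl to hexyl brings no visible gain in inhibition, and the step reads an at least 1.4-fold higher number from compound 2 to compound 3 (0.15 log units; that floor lies within the scatter), so the real size of the step is unknown and what can be read of it is not separated from the ordinary variation between repeated measurements. Compound 2 therefore remains the only compound here with an actual number, and the series now presses against the top of the measurable range: the limit of > 100000 nM in this assay, at which 2 of the 3 values shown sit.

With only butyl and hexyl at this place, and one of those a limit, no trend with chain length can be drawn, and a single step cannot show whether butyl is close to the best length. On these data alone, whether a propyl or pentyl chain in this place, or an amine or a carboxylic acid in place of the chain, would give a clearly lower number in this assay stays open.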